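Chloro on a second aromatic carbon of compound 1

A few compounds are considered here, and "the series" means these few. Any claim that something is new, unique, unknown or untested is made for them only; others in the source may bear on it.

Going by the values given here, in a functional assay on HL-60 cells (Homo sapiens) for antiproliferative activity, read by sulforhodamine B assay, with a stated time of 48 h (a lower number here means a stronger inhibitor of growth, a higher number a weaker inhibitor of growth), compound 1 (`O=C(/C=C/c1cccc(S(=O)(=O)c2ccc3ccccc3n2)c1)NO`) gives 290 nM, the lower of the two numbers measured so far. Its chloro counterpart, compound 2 (`O=C(/C=C/c1cccc(S(=O)(=O)c2ccc3cc(Cl)ccc3n2)c1)NO`), gives 1330 nM. Compound 3 (`O=C(/C=C/c1cccc(S(=O)(=O)c2ccc3cccc(Cl)c3n2)c1)NO`) has not yet been measured. It differs from compound 1 by chloro in place of hydrogen on an aromatic carbon. Among the compounds with values here, the only measured step that bears on this is the same kind of replacement on a different aromatic carbon, a 4.6-fold higher number from compound 1 to compound 2 (0.66 log units; beyond the scatter). A single step at another carbon is a limited guide, so a higher number is expected in this assay, probably by less than that step, although a change within the scatter remains possible. The expected step is a 2.4-fold higher number from compound 1 to compound 3 (0.38 log units; beyond the scatter). Compound 3 is estimated at 700 nM, with an expected range of 220 nM to 2200 nM.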

Compound 3, concentration for 50% growth inhibition: 2640 nM
Compound 3: middle estimate off by 3.8-fold (0.58 log units), on the low side; the measured number lies above the stated range.
By their numbers in this assay, from the lowest: compound 1; then compounds 2 and 3 (each within the scatter of the next).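

Chloro on this carbon, ortho to a fused ring and meta to a fused ring, also raises the number in this assay, with a 9.1-fold higher number from compound 1 to compound 3 (0.96 log units; beyond the scatter), so the rise seen earlier is not confined to one carbon. Compounds 2 and 3 stand within the scatter of each other, which means this assay does not separate the two chloro placements, and compound 1, with hydrogen at both carbons, keeps the lowest number of the three. No measurement bearing on why chloro has this effect at either carbon is available. The compounds shown leave open whether the rise belongs to chloro itself or would also follow a smaller fluoro, a methyl, a methoxy or an amine on this carbon. They also leave open whether any group here could bring the number below that of compound 1.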